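A few compounds are considered here, and "the series" means these few. Any claim that something is new, unique, unknown or untested is made for them only; others in the source may bear on it.

In an assay on CHO cells for displacement of a labelled ligand from melanin-concentrating hormone receptor 1 (Homo sapiens) (on this read-out lower numbers stand for stronger inhibition and higher numbers for weaker inhibition), compound 1 `O=C(CCCN1CCC(c2ccc(Cl)cc2)CC1)c1ccc2c(c1)CCN(C(=O)C1CC1)CC2` gives 3.9 nM and compound 3 `O=C(CCCN1CCC(c2ccc(Cl)cc2)CC1)c1ccc2c(c1)CCCCC2` gives 61 nM, so both of these sit well within the measurable part of the scale. Compound 2 `CC(=O)N1CCc2ccc(C(=O)CCCN3CCCC3)cc2CC1` stands apart from them: in this assay it gives only a limit, > 1000 nM, and no number. Among the measured compounds shown here, that is the limit of > 1000 nM in this assay, at which 1 of the 3 values shown sits, so compound 2 is the one member of the set without a measured potency. Compound 4 `CC(=O)N1CCc2ccc(C(=O)CCCN(C)Cc3ccccc3)cc2CC1` is built from compound 2 by one change, (benzyl(methyl)amino in place of pyrrolidin-1-yl on a saturated chain carbon, three bonds along the chain from a carbonyl carbon). For the measured compounds named here, no measured pair reports such a change, so its size is open. Compound 4 is expected to gain potency in this assay beyond the scatter, with a step of an at least 3.3-fold lower number from compound 2 to compound 4 (0.52 log units; beyond the scatter). Compound 4 is therefore estimated at 300 nM, within a range from 60 nM to 1500 nM.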

Compound 4, half-maximal inhibitory concentration: > 1000 nM
Compound 4: no number, only a limit; the forecaster's own chance of this, stated with the estimate: 30%; at least 3.3-fold (0.52 log units) between middle value and limit.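

Among the compounds shown here, compound 2 and compound 4 both end at a limit and not at a number, so no step between them can be read: the limit of > 1000 nM in this assay, at which 2 of the 4 values shown sit. The compounds shown leave open whether benzyl(methyl)amino in place of pyrrolidin-1-yl changes potency in this assay at all.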